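The source may hold more compounds than are shown below. What is called first, only, known or untested is meant among the compounds shown, and "the series" means these compounds.

Compound 1 `C[C@@H]1CN(C(=O)[C@@H]2C[C@H](S(=O)(=O)c3ccccc3)C[C@H]2C(=O)NC2(C#N)CC2)C[C@H](C)O1` is tested in an assay on isolated protein for inhibition of cathepsin S (Homo sapiens), read by fluorescence, with a stated time of 20 min (a lower number here means a stronger inhibitor, a higher number a weaker inhibitor), where it gives 0.4 nM, the lowest of the three numbers measured here. Compound 2 `N#CC1(NC(=O)[C@@H]2C[C@@H](S(=O)(=O)c3ccccc3)C[C@H]2C(=O)N2CCCCC2)CC1` gives 0.8 nM in this assay, and compound 3 `N#CC1(NC(=O)[C@@H]2C[C@@H](S(=O)(=O)c3ccccc3)C[C@H]2C(=O)N2CCS(=O)(=O)CC2)CC1` gives 4 nM. The step of a 2.0-fold higher number from compound 1 to compound 2 (0.30 log units; within the scatter) lies within the scatter, whereas a 10-fold higher number from compound 1 to compound 3 (1.00 log units; beyond the scatter) and a 5.0-fold higher number from compound 2 to compound 3 (0.70 log units; beyond the scatter) reach beyond it.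

Compound 4 `N#CC1(NC(=O)[C@@H]2C[C@@H](S(=O)(=O)c3ccccc3)C[C@H]2C(=O)N2CCC2)CC1` has not yet been measured in this assay. It differs from compound 1 in one place: azetidin-1-yl in place of 2,6-dimethylmorpholin-4-yl on a carbonyl carbon. The most relevant comparison is the exchange of the same group for piperidin-1-yl, because a 2.0-fold higher number from compound 1 to compound 2 (0.30 log units; within the scatter) stays within the scatter; the larger loss appears only with 1,1-dioxothiomorpholin-4-yl in compound 3. A small saturated ring without hetero atoms beyond nitrogen therefore seems closer to the piperidin-1-yl case. Compound 4 is expected to give about 1.2 nM in this assay, between 0.4 nM and 4 nM. This estimate means a step of a 3.0-fold higher number from compound 1 to compound 4 (0.48 log units; beyond the scatter), expected to be small and to stay within or just beyond the scatter.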

Compound 4, half-maximal inhibitory concentration: 10 nM
The estimate for compound 4 lay 8.3-fold (0.92 log units) below the measured number, outside the stated range (above it).
By their numbers in this assay, from the lowest: compounds 1 and 2 (each within the scatter of the next); then compound 3; then compound 4.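

Azetidin-1-yl on this carbonyl carbon gives a 25-fold higher number from compound 1 to compound 4 (1.40 log units; beyond the scatter) and also a 13-fold higher number from compound 2 to compound 4 (1.10 log units; beyond the scatter), so a saturated ring whose only hetero atom is nitrogen does not by itself keep the number low. The earlier compounds shown here showed a clear loss only with 1,1-dioxothiomorpholin-4-yl, yet this smaller ring goes further still, with a 2.5-fold higher number from compound 3 to compound 4 (0.40 log units; beyond the scatter). This position is therefore less forgiving than compounds 1 and 2 suggested, and in this set the one four-membered ring gives the highest number.

A five-membered pyrrolidin-1-yl group or an open dimethylamino group would help show whether the number climbs steadily as the ring shrinks or jumps only at azetidin-1-yl. No measurement at hand accounts for the size of this loss.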